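The source may hold more compounds than are shown below. What is called first, only, known or untested is meant among the compounds shown, and "the series" means these compounds.

Of the compounds shown here, three have been tested in a functional assay on the whole organism for antagonist activity, with Rattus norvegicus as the target; on this read-out lower numbers stand for an effect already at smaller amounts and higher numbers for an effect only at larger amounts of compound. Compound 1 `C1=C(CCN2CCN(c3cccc4c3OCCO4)CC2)c2ccccc2CC1` gives 0.63 mg/kg, compound 3 `c1ccc2c(c1)CC2CN1CCN(c2cccc3c2OCCCO3)CC1` gives 0.63 mg/kg, and compound 2 `Clc1cccc2c1CC2CCN1CCN(c2cccc3c2OCCO3)CC1` gives 1.25 mg/kg. All three numbers lie within the usual scatter of one another, so none can be set apart from the rest. Compound 4 `c1ccc2c(c1)CC(CCN1CCN(c3cccc4c3OCCO4)CC1)C2` has not been measured. It differs from compound 2 by a group of 9 heavy atoms (9 carbon; one five-membered non-aromatic ring of carbon only, one six-membered aromatic ring of carbon only) in place of a group of 9 heavy atoms (8 carbon, 1 chlorine; one four-membered non-aromatic ring of carbon only, one six-membered aromatic ring of carbon only), on a saturated chain carbon, two bonds along the chain from an amine nitrogen in a ring. Among the compounds with values here, no pair of measured compounds differing in a single place is available, so no measured step guides this change. Because compound 1 gives 0.63 mg/kg and compound 3 gives 0.63 mg/kg with related cores, the expected step of a 2.0-fold lower number from compound 2 to compound 4 (0.30 log units; within the scatter) is small, toward a lower number, and within the scatter. Compound 4 is expected to give 0.63 mg/kg, with a range from 0.3 mg/kg to 1.25 mg/kg.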

Compound 4, minimum effective dose: 0.16 mg/kg
Compound 4: middle estimate off by 3.9-fold (0.60 log units), on the high side; the whole stated range lies above it.
By their numbers in this assay, from the lowest: compound 4; then compounds 1, 3 and 2 (each within the scatter of the next).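

In this assay, within the data shown here, the 2,3-dihydro-1H-inden-2-yl group brings a 7.8-fold lower number from compound 2 to compound 4 (0.89 log units; beyond the scatter) and thus a step beyond the scatter, which the earlier compounds, all within the scatter of one another, could not show. This place on the chain therefore responds to the group it carries, even though both groups count 9 heavy atoms. The change removes the chlorine and alters the non-aromatic ring together, so a chlorine on the 2,3-dihydro-1H-inden-2-yl group would be needed to begin separating the two. Nothing shown here explains why the number falls.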